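Ring Swap on a Weak Amine: Estimating Compound 4

The source may hold more compounds than are shown below. What is called first, only, known or untested is meant among the compounds shown, and "the series" means these compounds.

Compound 1 `FC(F)(F)c1ccc(Nc2nc(N3CCN(C4CCC4)CC3)nc3c2CCN(c2ncccc2C(F)(F)F)CC3)cc1`: 24 nM
Compound 2 `CN1CCCCC1CNc1nc2c(c(Nc3ccc(C(F)(F)F)cc3)n1)CCN(c1ncccc1C(F)(F)F)CC2`: 1760 nM
Compound 3 `CNC1CCN(c2nc3c(c(Nc4ccc(C(F)(F)F)cc4)n2)CCN(c2ncccc2C(F)(F)F)CC3)C1`: 2790 nM

In a functional assay on HEK293 cells for antagonist activity at transient receptor potential cation channel subfamily V member 1 (Homo sapiens), read by FLIPR and calcium flux (a higher number here means a weaker inhibitor, a lower number a stronger inhibitor), compound 3 gives 2790 nM. It lies far from compound 1, as a 120-fold higher number from compound 1 to compound 3 (2.07 log units; beyond the scatter) shows, and close to compound 2, where a 1.6-fold higher number from compound 2 to compound 3 (0.20 log units; within the scatter) is within the scatter. Compound 4 `FC(F)(F)c1ccc(Nc2nc(NC3CCCNC3)nc3c2CCN(c2ncccc2C(F)(F)F)CC3)cc1` arises from compound 3 by the change ((piperidin-3-yl)amino in place of 3-(methylamino)pyrrolidin-1-yl on an aromatic carbon). For the measured compounds named here, the steps that bear on this are a 73-fold higher number from compound 1 to compound 2 (1.87 log units; beyond the scatter) and a 120-fold higher number from compound 1 to compound 3 (2.07 log units; beyond the scatter): both replacements of the 4-cyclobutylpiperazin-1-yl group of compound 1 by a smaller amine gave large losses, and the two resulting amines sit within the scatter of each other. Compound 4 carries another amine of that kind, so the step is expected to be a 1.1-fold lower number from compound 3 to compound 4 (0.05 log units; within the scatter), none beyond the scatter. Compound 4 is therefore estimated at 2500 nM, within a range from 800 nM to 8000 nM.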

Compound 4, half-maximal inhibitory concentration: > 5000 nM
Compound 4: only a limit was reported (the forecaster's own chance of this, stated with the estimate: 5%); middle value at least 2.0-fold (0.30 log units) away from the limit.
By their numbers in this assay, from the lowest: compound 1; then compounds 2 and 3 (each within the scatter of the next). At a limit, above all of these: compound 4.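

Compound 4 is reported only as a limit, not as a number: the limit of > 5000 nM in this assay, at which 1 of the 4 values shown sits.

Exchanging the five-membered ring of 3-(methylamino)pyrrolidin-1-yl for the six-membered ring of (piperidin-3-yl)amino, with the same heavy atoms, gives an at least 1.7-fold higher number from compound 3 to compound 4 (0.25 log units; that floor lies within the scatter), so this change brings no gain, though a real loss cannot be read from that floor. The floors of an at least 2.8-fold higher number from compound 2 to compound 4 (0.45 log units; beyond the scatter) and an at least 200-fold higher number from compound 1 to compound 4 (2.31 log units; beyond the scatter) both lie beyond the scatter, so this amine also falls far short of 4-cyclobutylpiperazin-1-yl.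

As far as these compounds go, the true value of compound 4 remains open. So does whether a smaller piperazine, such as 4-methylpiperazin-1-yl, or a morpholin-4-yl group on this aromatic carbon would recover the strength seen with 4-cyclobutylpiperazin-1-yl.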